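One more fluoro on a series at its limit

The source may hold more compounds than are shown below. What is called first, only, known or untested is meant among the compounds shown, and "the series" means these compounds.

Of the compounds shown here, three have been tested in an ADME assay on Raji cells (Homo sapiens) for cytotoxicity, with a stated time of 72 h (a higher number here means that more compound is needed for the effect, a lower number that less compound is needed), and none of them yields an actual number. Compound 1 (`Cc1cc(NC(=O)Nc2ccccc2N)c2ccccc2n1`) gives > 25000 nM as a limit of the assay. Compound 2 (`Cc1ccc(NC(=O)Nc2cc(C)nc3ccccc23)cc1`) gives > 25000 nM as a limit too. As far as these compounds go, compound 3 (`Cc1cc(NC(=O)Nc2ccc(F)cc2)c2ccccc2n1`) also reads > 25000 nM as a limit, so its true position is unknown. The whole set rests on the limit of > 25000 nM in this assay, at which 3 of the 3 values shown sit, and on no measured number.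

Compound 4 (`Cc1cc(NC(=O)Nc2ccc(F)cc2F)c2ccccc2n1`) is compound 3 with one change (fluoro in place of hydrogen on an aromatic carbon), fluoro in place of hydrogen on an aromatic carbon, ortho to a large group and meta to a fluoro group. The nearest measured change, fluoro in place of methyl on an aromatic carbon, is a step that the two limits leave unreadable from compound 2 to compound 3 and so gives no size to borrow. The swaps on the amide-type nitrogen, a step that the two limits leave unreadable from compound 1 to compound 2 and a step that the two limits leave unreadable from compound 1 to compound 3 alike, give none either.

Compound 4 is expected to stay with the others, since compound 3 reads > 25000 nM as a limit. The estimated change is a number no higher from compound 3 to compound 4 (the limit leaves the size open) and no step beyond the scatter is expected in this assay in either direction. For compound 4 the estimated value is 25000 nM with an expected range from 12000 nM to 40000 nM and most likely only a limit will be reported.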

Compound 4, half-maximal effective concentration: > 25000 nM
Compound 4 was reported as a limit (the forecaster's own chance of this, stated with the estimate: 85%); the middle value lies on the limit itself.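

In this assay compound 4 gives > 25000 nM, which is a limit and not a number. Compound 3 also stands at a limit, so the change from compound 3 to compound 4 has no readable size. The concentration that any of the four compounds needs for the effect stays open, and the set offers only this: the limit of > 25000 nM in this assay, at which 4 of the 4 values shown sit.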